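Guanosine analogues: maximal B cell response in mouse

The source may hold more compounds than are shown below. What is called first, only, known or untested is meant among the compounds shown, and "the series" means these compounds.

Measured so far:
compound 1 `Nc1nc(O)c2c(n1)n(C1OC(CO)[C@@H](O)[C@H]1O)c(=O)n2Cc1ccc([N+](=O)[O-])cc1` — 147%
compound 2 `C=CCn1c(=O)n(CCCC)c2nc(N)nc(O)c21` — 77%

Two compounds have a number in a functional assay on the whole organism (B cells) with Mus musculus as the target; on this read-out higher numbers stand for larger maximal responses and lower numbers for smaller maximal responses. Compound 1 stands highest of the two, and compound 2 lies lower by a gap that is beyond the usual scatter. For the measured compounds named here, no pair of measured compounds differs in one place only, so no measured step is available to guide the next change.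

Compound 3 `Nc1nc(O)c2c(n1)n(C1OC(CO)[C@@H](O)[C@H]1O)c(=O)n2C/C=C/c1ccccc1` is the next compound for this assay. It differs from compound 1 in one place: 2-phenylethenyl in place of 4-nitrophenyl on a saturated chain carbon bound to an aromatic nitrogen. Going by the values given here, with both hydrogen-bond acceptors of the leaving group gone and none entering, and with no measured step to lean on, the direction is uncertain; a moderate decrease beyond the scatter is taken as the working expectation, so that the step is expected to be a number 27 percentage points lower from compound 1 to compound 3 (beyond the scatter). Compound 3 is therefore estimated at 120%, within a range from 60% to 170%.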

Compound 3, largest response reached (reported as maximal response), in percent of the reference or control that the assay uses: 73%
Compound 3: the middle estimate sits 47 percentage points above what was measured; the range from low to high includes it.
By their numbers in this assay, from the lowest: compounds 3 and 2 (each within the scatter of the next); then compound 1.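

In this assay, for the compounds shown here, the first measured step at this position is large: 2-phenylethenyl in place of 4-nitrophenyl on a saturated chain carbon bound to an aromatic nitrogen gives a number 74 percentage points lower from compound 1 to compound 3 (beyond the scatter) on the same core. The maximal response is therefore sensitive to this group, even though a six-membered aromatic ring of carbon only is present on both sides of the change and the heavy-atom count moves only from 9 to 8, with the 2 hydrogen-bond acceptors leaving and none entering. No measurement on hand bears on why the number falls.

The compounds shown leave open whether the step follows from the loss of the nitro group or from the ethenyl link, as both change at once. An unsubstituted benzyl or a 4-cyanobenzyl group in this place would separate the two.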